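Moving the Bromine on the Benzyl Group

The source may report more compounds than this note shows. Statements on the series, on what has been measured and on what is new or still open speak of the compounds shown alone.

Compound 1, `Cc1cc(Nc2ccn(Cc3cccc4ccccc34)n2)n2nc(SCc3ccc(Br)cc3)nc2n1`: 3240 nM
Compound 2, `Cc1cc(Nc2cc(-c3ccccc3)[nH]n2)n2nc(SCc3cccc(Br)c3)nc2n1`: 4820 nM
Compound 3, `Cc1cc(Nc2ccn(Cc3ccc(C(F)(F)F)cc3)n2)n2nc(SCc3ccc(Br)cc3)nc2n1`: 2590 nM

All three compounds were tested in a functional assay on MGC-803 cells (Homo sapiens) for inhibition, read by MTT assay, with a stated time of 72 h; on this read-out lower numbers stand for stronger inhibition and higher numbers for weaker inhibition. Compound 2 lies within the usual scatter of both compound 1 and compound 3, so on this read-out the three are not distinguishable from one another.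

Compound 4, `Cc1cc(Nc2cc(-c3ccccc3)[nH]n2)n2nc(SCc3ccc(Br)cc3)nc2n1`, has not yet been measured. It differs from compound 2 in one place: 4-bromophenyl in place of 3-bromophenyl on a saturated chain carbon bound to a sulfur. Among the measured compounds shown here, the only measured single step, a 1.3-fold lower number from compound 1 to compound 3 (0.10 log units; within the scatter), alters a different part of the molecule and stayed within the scatter, so it gives no direct guidance on this change. Compounds 1 and 3 both carry the 4-bromophenyl group that enters here, but they also differ from compound 2 elsewhere, so their numbers can only be taken as a loose hint that this group is compatible with activity in the same range. For the measured compounds named here, with no direct precedent, the expectation is that the step of a 1.3-fold lower number from compound 2 to compound 4 (0.13 log units; within the scatter) will stay within the scatter. Compound 4 is therefore estimated at 3600 nM, with a range from 1500 nM to 8500 nM.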

Compound 4, half-maximal inhibitory concentration: 1110 nM
Beside the measured number, compound 4's estimate is 3.2-fold (0.51 log units) above it, outside the stated range (below it).
By their numbers in this assay, from the lowest: compound 4; then compounds 3, 1 and 2 (each within the scatter of the next).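

Moving the bromine is the first single change in this set that shifts the number beyond the usual scatter: in this assay the step is a 4.3-fold lower number from compound 2 to compound 4 (0.64 log units; beyond the scatter). The groups that leave and enter have the same atoms and the same counts of rings, hydrogen-bond donors and acceptors, so the two compounds differ only in 3-bromophenyl versus 4-bromophenyl on a saturated chain carbon bound to a sulfur, and that difference alone is enough to change the read-out at this position. Nothing measured here accounts for the difference.

The compounds shown leave open whether the same change would have a similar effect in compounds carrying the naphthalen-1-yl or 4-(trifluoromethyl)phenyl groups of compound 1 and compound 3, since no 3-bromophenyl partner of either stands here for comparison. They also leave open whether bromine itself matters at this position, as a plain phenyl, a 4-chlorophenyl or a 4-methoxyphenyl group in its place could give a number close to that of compound 4 or a very different one.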